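The source may report more compounds than this note shows. Statements on the series, on what has been measured and on what is new or still open speak of the compounds shown alone.

Three related compounds were tested in a functional assay on ACHN cells (Homo sapiens) for cytotoxicity, read by sulforhodamine B assay, with a stated time of 48 h; on this read-out higher numbers stand for weaker inhibition of growth and lower numbers for stronger inhibition of growth. Compound 1 `Nc1nc(Cl)c2ncn(Cc3ccc(CCl)cc3)c2n1` gives 25100 nM there. Compound 2 `ClCc1cccc(Cn2cnc3c(Cl)nc(Cl)nc32)c1` gives 3710 nM in this assay, and compound 3 `ClCc1ccc(Cn2cnc3c(Cl)nc(Cl)nc32)cc1` gives 5250 nM. The numbers for compound 2 and compound 3 lie within the usual scatter of each other, so no order can be read between them. Compound 2 and compound 3 are built from the same atoms joined differently, and the difference between the two cores is not broken down here.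

Compound 3 and compound 1 differ in one place:
amino in place of chloro on an aromatic carbon
This change gave a step of a 4.8-fold higher number from compound 3 to compound 1 (0.68 log units; beyond the scatter), a modest weakening of growth inhibition.

Compound 4 `Nc1nc(Cl)c2ncn(Cc3cccc(CCl)c3)c2n1` has not yet been measured. It differs from compound 2 by
amino in place of chloro on an aromatic carbon
The place of this change reads word for word as the change from compound 3 to compound 1, so it is the same change, occurring for the second time among these compounds. If it acts as before, a step of a 4.6-fold higher number from compound 2 to compound 4 (0.66 log units; beyond the scatter) is expected, a size that rests on the earlier step of a 4.8-fold higher number from compound 3 to compound 1 (0.68 log units; beyond the scatter). The estimate for compound 4 in this assay is 17000 nM, expected to fall between 7000 nM and 40000 nM.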

Compound 4, concentration for total growth inhibition: 8710 nM
Compound 4: middle estimate off by 2.0-fold (0.29 log units), on the high side; the measured number falls inside the stated range.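

Putting amino in place of chloro on the aromatic carbon between two ring nitrogen atoms again weakened growth inhibition in this assay, with a 2.3-fold higher number from compound 2 to compound 4 (0.37 log units; beyond the scatter). The two steps run in the same direction, and their sizes cannot be told apart: the same change on two cores in this assay, a 4.8-fold higher number (0.68 log units; beyond the scatter) from compound 3 to compound 1 and a 2.3-fold higher number (0.37 log units; beyond the scatter) from compound 2 to compound 4, 2.0-fold (0.31 log units) apart, within the scatter of two such steps. This shows that, across these two pairs, the change carried over from one core to the other with a similar effect, but two pairs cannot show that it would do the same on any further core, and the numbers do not explain why growth inhibition weakens.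

As far as these compounds go, it remains open how growth inhibition would respond to a different group on that same carbon, such as methylamino or methoxy. Every compound shown also keeps its chloromethyl group, and what a hydroxymethyl group or a longer chain in its place would do remains equally open.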